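The compounds below may be only part of what the source reports. "The series", "measured", "known", "first", "only" and "open" are said of these compounds alone.

Measured in a physicochemical assay for lipophilicity, at pH 7.4; a lower number here means a more polar compound, a higher number a more lipophilic compound:
- Compound 1 `COc1ccc(NC(=O)[C@H]2CCCN2C(=O)C2(c3cccc(Cl)c3)CCCC2)nc1`: 6.8
- Compound 2 `O=C(Nc1ccc2[nH]ccc2n1)[C@H]1CCCN1C(=O)C1(c2cccc(Cl)c2)CCCC1`: 5.9
- Compound 3 `O=C1Cc2cc(NC(=O)[C@H]3CCCN3C(=O)C3(c4cccc(Cl)c4)CCCC3)ccc2N1`: 5

Compound 3 stands lowest of the three on this assay. Compound 4 `O=C(Nc1ccc2[nH]ncc2c1)[C@H]1CCCN1C(=O)C1(c2cccc(Cl)c2)CCCC1` has not yet been measured. It differs from compound 3 as follows: a group of 9 heavy atoms (7 carbon, 2 nitrogen; one five-membered aromatic ring with 2 hetero atoms, one six-membered aromatic ring of carbon only) in place of a group of 10 heavy atoms (8 carbon, 1 nitrogen, 1 oxygen; one five-membered non-aromatic ring with 1 hetero atom, one six-membered aromatic ring of carbon only), on an amide-type nitrogen. The group that enters is 1H-indazol-5-yl, on an amide-type nitrogen. The nearest guide is a number 0.90 log units lower from compound 2 to compound 3 (beyond the scatter), and the group now leaving entered there. The same group also entered in a number 1.80 log units lower from compound 1 to compound 3 (beyond the scatter), a large step. Among the measured compounds shown here, no measured compound carries 1H-indazol-5-yl, so a rise of modest size is expected, reversing part of those falls. The expected step is a number 0.70 log units higher from compound 3 to compound 4 (beyond the scatter). Compound 4 is estimated at 5.7, with an expected range of 5.2 to 6.2.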

Compound 4, distribution coefficient: 5.4
Beside the measured number, compound 4's estimate is 0.30 log units above it, and the stated range covers the measured number.
By their numbers in this assay, from the lowest: compound 3; then compound 4; then compound 2; then compound 1.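

At this amide-type nitrogen, 1H-indazol-5-yl gives a number 1.40 log units lower from compound 1 to compound 4 (beyond the scatter) in this assay and so joins the other two-ring groups in standing lower than 5-methoxypyridin-2-yl. Even two groups with the same heavy atoms (7 carbon, 2 nitrogen) are separated, with a number 0.50 log units lower from compound 2 to compound 4 (beyond the scatter) while a number 0.40 log units higher from compound 3 to compound 4 (beyond the scatter) places compound 4 between the other two-ring compounds. Nothing available here explains these differences.

On these data alone, whether an amine or a carboxylic acid on 1H-indazol-5-yl would shift the number further stays open. So does whether this order of groups would hold on another core.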